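Phenoxy to hydroxy: solubility working notes on the series

The source may report more compounds than this note shows. Statements on the series, on what has been measured and on what is new or still open speak of the compounds shown alone.

Two compounds of the series have been run in a physicochemical assay for solubility, at pH 6.8; a lower number here means a less soluble compound, a higher number a more soluble compound. Compound 1 `O=[N+]([O-])c1cn2c(n1)OC[C@@H](NCc1ccc(OC(F)(F)F)c(Oc3ccccc3)c1)C2` returns only a limit in this assay, < 2 ug/mL, and so its place among the numbers shown is that limit rather than a measured value; the relevant observation is the limit of < 2 ug/mL in this assay, at which 1 of the 2 values shown sits. Compound 2 `O=[N+]([O-])c1cn2c(n1)OC[C@@H](NCc1ccc(OC(F)(F)F)cc1OCC1CC1)C2` gives a measured figure in this assay, 6 ug/mL. For the measured compounds named here, since one of the pair sits at a limit, no counted step between them is given here; the two values show only that compound 2 produced a number where compound 1 did not.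

Compound 3 `O=[N+]([O-])c1cn2c(n1)OC[C@@H](NCc1ccc(OC(F)(F)F)c(O)c1)C2` is not yet measured in this assay. Relative to compound 1 the change is hydrogen in place of phenyl on an oxygen on an aromatic ring, that is, phenoxy to hydroxy on the aromatic ring. Going by the values given here, no measured pair in the set spans this change, so no measured step is available to calibrate it. The step is nonetheless expected to be upward and beyond the usual scatter, estimated as an at least 7.5-fold higher number from compound 1 to compound 3 (0.87 log units; beyond the scatter). Compound 3 is accordingly expected to give about 15 ug/mL in this assay, within an estimated range from 4 ug/mL to 60 ug/mL.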

Compound 3, solubility: 56 ug/mL
For compound 3 the middle estimate is 3.7-fold (0.57 log units) below the measured one; measured number inside the range.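

In this assay, the oxygen on the aromatic ring now has a readable change: hydrogen in place of phenyl gives an at least 28-fold higher number from compound 1 to compound 3 (1.44 log units; beyond the scatter). For the compounds shown here, this is the first step that rests on a single change, and it shows that this oxygen is a place where one replacement moves the read-out beyond the scatter, from a limit to a measured number. Compound 1 stands at a limit, so the step gives only a minimum for the change and its full size stays unknown: the limit of < 2 ug/mL in this assay, at which 1 of the 3 values shown sits.

The compounds shown leave open whether the rise belongs to the free hydroxy group or simply to the departure of the phenyl, a question that a methoxy or ethoxy group on the same oxygen would separate. They also leave open how far solubility in this assay can be taken by a larger replacement on this oxygen, such as a chain ending in an amine or a carboxylic acid, and whether the same change would give a comparable step with the cyclopropylmethoxy group of compound 2 in the molecule.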